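Swapping the amide cap in a pair of antiproliferative flavonol amides

The source may hold more compounds than are shown below. What is called first, only, known or untested is meant among the compounds shown, and "the series" means these compounds.

Compound 1 `Cc1ccccc1C(=O)Nc1cccc(-c2oc3cc(-c4ccc(F)cc4)ccc3c(=O)c2O)c1` was tested in a functional assay on MDA-MB-231 cells (Homo sapiens) for antiproliferative activity, read by CCK-8 assay, with a stated time of 72 h (on this read-out lower numbers stand for stronger inhibition and higher numbers for weaker inhibition), and gave 4910 nM, the highest of the two numbers measured, meaning the weaker of the two inhibitors. Its nearest neighbour is compound 2 `O=C(Nc1cccc(-c2oc3cc(-c4ccc(F)cc4)ccc3c(=O)c2O)c1)c1ccc(Cl)nc1`, which in this assay gives 1760 nM; the step of a 2.8-fold lower number from compound 1 to compound 2 (0.45 log units; beyond the scatter) came from replacing the 2-methylphenyl group on the carbonyl carbon with a 6-chloropyridin-3-yl group. Compound 3 `O=C(Nc1cccc(-c2oc3cc(-c4ccc(F)cc4)ccc3c(=O)c2O)c1)c1ccc(-c2ccccc2)cc1` has not yet been measured. It differs from compound 1 by 4-phenylphenyl in place of 2-methylphenyl on a carbonyl carbon. Going by the values given here, only one measured step bears on this change, and it concerns a different replacement of the same group, so the guidance is thin: it shows that changing the group on the carbonyl carbon can move the number beyond the scatter, but a 4-phenylphenyl group has no measured precedent here. A modest lowering of the number, smaller than the step seen for compound 2 and possibly within the scatter, is the expectation. Compound 3 is therefore expected to give about 3000 nM in this assay, within a range of 1000 nM to 9000 nM, an expected step of a 1.6-fold lower number from compound 1 to compound 3 (0.21 log units; within the scatter).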

Compound 3, half-maximal inhibitory concentration: 63200 nM
For compound 3 the middle estimate is 21-fold (1.32 log units) below the measured one, outside the stated range (above it).
By their numbers in this assay, from the lowest: compound 2; then compound 1; then compound 3.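

In this assay, going by these compounds alone, replacing 2-methylphenyl with 4-phenylphenyl on the carbonyl carbon gives a 13-fold higher number from compound 1 to compound 3 (1.11 log units; beyond the scatter), so this place can also move the number sharply upward, whereas the only earlier step, a 2.8-fold lower number from compound 1 to compound 2 (0.45 log units; beyond the scatter), was modest and went downward. The contrast is larger still between the two other groups at this place, with 4-phenylphenyl in place of 6-chloropyridin-3-yl giving a 36-fold higher number from compound 2 to compound 3 (1.56 log units; beyond the scatter), which shows that the choice of group here can decide much of the activity of these amides even though the rest of the molecule stays the same. The entering group has 12 heavy atoms and two aromatic rings against 7 heavy atoms and one ring in 2-methylphenyl, but nothing measured here explains the loss of activity.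

The three compounds cannot separate the effect of the second ring from the effect of where it is attached, and a 3-phenylphenyl or a plain phenyl group would bear on that question. As far as these compounds go, how a ring without aromatic character, such as cyclohexyl, or a group carrying an amine would behave at this place also remains open.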